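From chloro to methoxy: a step without direct precedent

The source may hold more compounds than are shown below. What is called first, only, known or untested is meant among the compounds shown, and "the series" means these compounds.

In an ADME assay on the whole organism (Rattus norvegicus) for pharmacokinetics, read by HPLC, at a dose of 3 mg/kg by the oral route (on this read-out lower numbers stand for lower exposure and higher numbers for higher exposure at the dose given), compound 1 (`O=C(c1cc(Cl)c(O)c(C(F)(F)F)c1)N1CS(=O)(=O)c2ccccc21`) gives 16400 nM. For the measured compounds named here, the only other measured compound, compound 2 (`CSc1cc(C(=O)N2CS(=O)(=O)c3ccccc32)cc(Cl)c1O`), gives 12500 nM, so the two lie within the scatter of each other and compound 1 stands level with it. Compound 3 (`COc1cc(C(=O)N2CS(=O)(=O)c3ccccc32)cc(C(F)(F)F)c1O`) has not yet been measured. It differs from compound 1 in one place: methoxy in place of chloro on an aromatic carbon. This is methoxy in place of chloro on an aromatic carbon, ortho to a hydroxy group. Going by the values given here, the one measured step, a 1.3-fold lower number from compound 1 to compound 2 (0.12 log units; within the scatter), replaces the trifluoromethyl group rather than the chloro, so it bears on this change only indirectly. Among the compounds with values here, it is still the sole guide, and it was small. No step beyond the scatter is therefore expected in this assay. The expected step is a 1.4-fold lower number from compound 1 to compound 3 (0.14 log units; within the scatter). For compound 3 the estimated value is 12000 nM, within an expected range of 4500 nM to 30000 nM.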

Compound 3, maximal plasma concentration: 10300 nM
For compound 3 the middle estimate is 1.2-fold (0.07 log units) above the measured one; measured number inside the range.
By their numbers in this assay, from the lowest: compounds 3, 2 and 1 (each within the scatter of the next).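

For the compounds shown here, until this point only the trifluoromethyl group had been exchanged, so this is the first reading at the chloro position, ortho to a hydroxy group. In this assay, moving to methoxy gives a 1.6-fold lower number from compound 1 to compound 3 (0.20 log units; within the scatter) and so shows that, on this read-out, a single chlorine can give way to a group of 2 heavy atoms carrying a hydrogen-bond acceptor without a step beyond the scatter. No available measurement explains this outcome.

With methoxy as the only replacement shown at this position, one step cannot establish a trend across other groups. Going by these compounds, it remains open whether an amine, a carboxylic acid or a longer chain such as butoxy would also stay within the scatter or would shift exposure clearly in either direction.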